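This account rests on a few compounds, and the source may have more. Where it says the series, first, only, none or still open, it means among the compounds named here.

Compound 1 `CNC(=O)c1ccc(-c2nc(COc3cc(OC)cc4oc(-c5cn6nc(OC)sc6n5)cc34)cs2)cc1`: in a functional assay on HEK293 cells for antagonist activity at proteinase-activated receptor 4 (Homo sapiens), read by FLIPR and calcium flux, with a stated time of 30 min (on this read-out higher numbers stand for weaker inhibition and lower numbers for stronger inhibition), compound 1 gives 0.4 nM.
Compound 2 `COc1cc(OCc2csc(-c3ccc(C(=O)O)cc3)n2)c2cc(-c3cn4nc(OC)sc4n3)oc2c1`: in this assay compound 2 gives 1.1 nM.

Compound 2 holds the higher of the two numbers, set apart by a 2.8-fold higher number from compound 1 to compound 2 (0.44 log units; beyond the scatter). Compound 3 `COc1cc(OCc2csc(N3CCOCC3=O)n2)c2cc(-c3cn4nc(OC)sc4n3)oc2c1` differs from compound 2 by 3-oxomorpholin-4-yl in place of 4-carboxyphenyl on an aromatic carbon. Going by the values given here, no measured step covers this exchange; the only step known, a 2.8-fold higher number from compound 1 to compound 2 (0.44 log units; beyond the scatter), swaps just the group on the carbonyl carbon and stays modest, whereas here the whole 4-carboxyphenyl is exchanged. Compound 3 is therefore expected to show a larger shift toward weaker inhibition, an 11-fold higher number from compound 2 to compound 3 (1.04 log units; beyond the scatter). Compound 3 is estimated at 12 nM, with a range of 2 nM to 80 nM.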

Compound 3, half-maximal inhibitory concentration: 1.7 nM
For compound 3 the middle estimate is 7.1-fold (0.85 log units) above the measured one, outside the stated range (below it).
By their numbers in this assay, from the lowest: compound 1; then compounds 2 and 3 (each within the scatter of the next).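

At this aromatic carbon, in this assay, the non-aromatic 3-oxomorpholin-4-yl can replace the entire 4-carboxyphenyl with no shift beyond the scatter (a 1.5-fold higher number from compound 2 to compound 3 (0.19 log units; within the scatter)), so an aromatic ring at this place is not required among these compounds. Set against the 4-(methylcarbamoyl)phenyl, the same exchange costs a modest amount (a 4.3-fold higher number from compound 1 to compound 3 (0.63 log units; beyond the scatter)). No available data explain this tolerance.

Open, going by these compounds, is whether the ring carbonyl of the 3-oxomorpholin-4-yl matters, which a plain morpholine would test. Also open, on these data alone, is whether an open-chain amine at this carbon would hold up as well.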